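Fluoro for hydroxy on the shared core

The compounds below may be only part of what the source reports. "The series", "measured", "known", "first", "only" and "open" are said of these compounds alone.

In a functional assay on HepG2 cells (Homo sapiens) for cytotoxicity, read by MTT assay (a higher number here means a weaker inhibitor, a lower number a stronger inhibitor), compound 2 `C=C1C(=O)[C@]23C[C@@]1(O)CC[C@H]2[C@@]12C=CC(=O)[C@](C)(C(=O)O1)[C@H]2[C@@H]3C(=O)OC` gives 37200 nM, and compound 1 `C=C1C(=O)[C@]23C[C@@]1(Cl)CC[C@H]2[C@@]12C=CC(=O)[C@](C)(C(=O)O1)[C@H]2[C@@H]3C(=O)OC` gives 39800 nM. Within the data shown here, these are the only two numbers so far, and they lie within the scatter of each other.

The next structure is compound 3 `C=C1C(=O)[C@]23C[C@@]1(F)CC[C@H]2[C@@]12C=CC(=O)[C@](C)(C(=O)O1)[C@H]2[C@@H]3C(=O)OC`, with fluoro in place of hydroxy on a saturated ring carbon.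

Among the measured compounds shown here, one measured step bears on this change, hydroxy in place of chloro on the same carbon: a 1.1-fold lower number from compound 1 to compound 2 (0.03 log units; within the scatter). For the measured compounds named here, no measured compound yet carries fluoro, so this single step is a thin basis. With nothing else to go on, no step beyond the scatter is expected in this assay. The estimated step is a 1.0-fold higher number from compound 2 to compound 3 (0.01 log units; within the scatter). For compound 3 the expected value is 38000 nM, with an estimated range of 20000 nM to 70000 nM.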

Compound 3, half-maximal inhibitory concentration: 40600 nM
Compound 3: middle estimate off by 1.1-fold (0.03 log units), on the low side; low and high end bracket the measured number.
By their numbers in this assay, from the lowest: compounds 2, 1 and 3 (each within the scatter of the next).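

In this assay fluoro on this saturated ring carbon adds a third group to the comparison, and neither the exchange for hydroxy (a 1.1-fold higher number from compound 2 to compound 3 (0.04 log units; within the scatter)) nor the exchange for chloro (a 1.0-fold higher number from compound 1 to compound 3 (0.01 log units; within the scatter)) leaves the scatter. Hydroxy counts one hydrogen-bond donor and one hydrogen-bond acceptor and fluoro counts neither, yet the read-out does not separate these two groups, so across compounds 1, 2 and 3 the change of group at this carbon gives no step beyond the scatter. No supporting data are available to account for this result.

Open, on these data alone, is whether this position stays as flat with a larger or differently built group, such as an amine, a carboxylic acid, a methoxy group or a longer alkyl chain. Also open, as far as these compounds go, is whether any group on this carbon can move the number beyond the scatter.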